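The compounds below may be only part of what the source reports. "The series", "measured", "known", "first", "only" and "open" are said of these compounds alone.

For the measured compounds named here, in an assay on isolated protein for inhibition of protein kinase C delta type (Homo sapiens), read by TR-FRET, with a stated time of 2 h (on this read-out lower numbers stand for stronger inhibition and higher numbers for weaker inhibition), compound 2 `CO[C@H]1CC[C@@H](Nc2cc(NCc3cnccc3C(F)(F)F)ncc2C#N)CC1` gives 5000 nM, and that is the only plain number among the values shown. Compound 1 `N#Cc1cnc(NCc2cnccc2C(F)(F)F)cc1N[C@H]1C[C@@H](O)C1` sits at a limit of the assay, > 10000 nM. Of the two values shown, one therefore rests at the limit of > 10000 nM in this assay, at which 1 of the 2 values shown sits, so compound 2 stands as the sole fixed point. Going by the values given here, the single measured step, an at least 2.0-fold lower number from compound 1 to compound 2 (0.30 log units; that floor lies within the scatter), runs from that limit to the one number and is only a floor within the scatter.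

Compound 3 `N#Cc1cnc(NCc2cnccc2C(F)(F)F)cc1NC[C@H]1CC[C@H](O)CC1` has not yet been measured in this assay. It differs from compound 2 in one place: (4-hydroxycyclohexyl)methyl in place of 4-methoxycyclohexyl on a nitrogen on an aromatic ring. Among the compounds with values here, the measured step is the only comparison that touches the same nitrogen, and it is too small to set a direction, so it gives little to lean on; compound 3 brings back a hydroxyl while keeping the six-membered ring of compound 2. With so thin a record, compound 3 is expected to give 7000 nM, with a range from 2500 nM to 30000 nM. That estimate means a step of a 1.4-fold higher number from compound 2 to compound 3 (0.15 log units; within the scatter) from compound 2 to compound 3, expected to stay within the scatter.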

Compound 3, half-maximal inhibitory concentration: 2000 nM
For compound 3 the middle estimate is 3.5-fold (0.54 log units) above the measured one; the whole stated range lies above it.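

In this assay, the change on this nitrogen now gives a step beyond the scatter, a 2.5-fold lower number from compound 2 to compound 3 (0.40 log units; beyond the scatter), where the earlier comparison offered only a floor within it. The step arises with no change in the count of heavy atoms and with the six-membered carbon ring kept, for the two substituents hold the same atoms joined differently: (4-hydroxycyclohexyl)methyl carries a hydrogen-bond donor that 4-methoxycyclohexyl lacks, and it reaches the nitrogen through an added carbon link. The step of an at least 5.0-fold lower number from compound 1 to compound 3 (0.69 log units; beyond the scatter) is only a floor, since compound 1 rests at a limit and not at a number: the limit of > 10000 nM in this assay, at which 1 of the 3 values shown sits.

The hydroxyl and the carbon link change together from compound 2 to compound 3, so the compounds shown leave open which of them goes with the step, a question that 4-hydroxycyclohexyl or (4-methoxycyclohexyl)methyl on the same nitrogen would address. They also leave open how an amine or a carboxylic acid in place of the hydroxyl, or a longer chain between the ring and the nitrogen, would read against compound 3 at 2000 nM.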